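Phosphatase inhibition: swapping the amide substituent in compound 1

The compounds below may be only part of what the source reports. "The series", "measured", "known", "first", "only" and "open" are said of these compounds alone.

Measured so far:
compound 1, `O=C(COc1ccc2cc(C(O)(C(F)(F)F)C(F)(F)F)c(O)cc2c1)Nc1nc2ccccc2s1`, 10900 nM
compound 2, `Oc1c(-c2ccccc2)cccc1C(O)(C(F)(F)F)C(F)(F)F`, 157000 nM

In an assay on isolated protein for inhibition of receptor-type tyrosine-protein phosphatase C (Homo sapiens), read by spectrophotometry (a lower number here means a stronger inhibitor, a higher number a weaker inhibitor), compound 1 gives 10900 nM, the lower of the two numbers; compound 2 gives 157000 nM, a gap that lies beyond the scatter. Compound 3 `O=C(COc1ccc2cc(C(O)(C(F)(F)F)C(F)(F)F)c(O)cc2c1)NCc1ccccc1` has not been measured. It differs from compound 1 in one place: benzyl in place of 1,3-benzothiazol-2-yl on an amide-type nitrogen. Within the data shown here, no measured pair carries this change, so the size of the step rests on expectation alone; a modest weakening, slightly beyond the scatter, seems plausible. For compound 3 the expected value in this assay is 25000 nM (range 8000 nM to 80000 nM). The expected step is a 2.3-fold higher number from compound 1 to compound 3 (0.36 log units; beyond the scatter).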

Compound 3, half-maximal inhibitory concentration: > 20000 nM
Compound 3 was reported as a limit (the forecaster's own chance of this, stated with the estimate: 10%); the middle value is on the limit's open side.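

In this assay compound 3 is reported only as a limit, > 20000 nM, not as a number. Benzyl in place of 1,3-benzothiazol-2-yl on the amide-type nitrogen gives an at least 1.8-fold higher number from compound 1 to compound 3 (0.26 log units; that floor lies within the scatter), so this first change at this place brings no lower number. The true size of the step cannot be read, because the result ends in a limit: the limit of > 20000 nM in this assay, at which 1 of the 3 values shown sits.

As far as these compounds go, whether benzyl costs anything at all stays open. Also open, from the compounds shown here alone, is what a smaller amide substituent, such as methyl, or a benzyl carrying a carboxylic acid would give at this nitrogen.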